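Amide Swap on a Core Without Measured Binding

The compounds below may be only part of what the source reports. "The series", "measured", "known", "first", "only" and "open" are said of these compounds alone.

Compound 1 `CS(=O)(=O)c1ccc(C(=O)NCCCC(=O)N2Cc3ccccc3C2)cc1[N+](=O)[O-]`: > 60000 nM
Compound 2 `CS(=O)(=O)c1ccc(C(=O)NCCCC(=O)N2CCCCC2)cc1[N+](=O)[O-]`: > 60000 nM

Both measured compounds share one core and differ only in the amide end. In an assay on isolated protein for inhibition of thyroid hormone receptor beta (Homo sapiens), read by fluorescence polarization (on this read-out lower numbers stand for stronger inhibition and higher numbers for weaker inhibition), compound 1 gives > 60000 nM, which is a limit of the assay rather than a number. Compound 2 likewise gives only a limit, > 60000 nM. Compound 2 therefore stands at the limit of > 60000 nM in this assay, at which 2 of the 2 values shown sit, together with compound 1. The step that the two limits leave unreadable from compound 1 to compound 2 cannot be read in size or direction from the two limits.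

Compound 3 `CN(Cc1ccccc1F)C(=O)CCCNC(=O)c1ccc(S(C)(=O)=O)c([N+](=O)[O-])c1` is the next compound, differing from compound 2 by (2-fluorobenzyl)(methyl)amino in place of piperidin-1-yl on a carbonyl carbon. For the measured compounds named here, the only step that bears on this change is the one from compound 1 to compound 2, and it is unreadable, so no size or direction can be carried over. Compound 3 is therefore expected to remain at the limit, with the estimated step of a number no higher from compound 2 to compound 3 (the limit leaves the size open) carrying no readable size, and compound 3 is estimated at 60000 nM within 20000 nM to 200000 nM.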

Compound 3, half-maximal inhibitory concentration: > 60000 nM
Compound 3 ended at the assay's limit; the forecaster's own chance of this, stated with the estimate: 85%; the middle value lies on the limit itself.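

Compound 3 also gives only a limit, so no new step can be read among compound 1, compound 2 and compound 3: the limit of > 60000 nM in this assay, at which 3 of the 3 values shown sit. The compounds shown leave open whether any amide end on the shared core gives a measurable value in this assay.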